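Chloro to hydrogen on the pendant ring of compound 3

This account rests on a few compounds, and the source may have more. Where it says the series, first, only, none or still open, it means among the compounds named here.

Measured compounds in a functional assay on HL-60 cells (Homo sapiens) for inhibition, read by MTT assay, with a stated time of 72 h; a lower number here means a stronger inhibitor, a higher number a weaker inhibitor:
compound 1 `Cc1nc(-c2ccccc2)c(C(=O)N2CCN(c3c(C)cccc3C)CC2)o1`, 146 nM
compound 2 `Cc1nc(-c2ccccc2)c(C(=O)N2CCN(c3cccc(C)c3C)CC2)o1`, 35 nM
compound 3 `Cc1ccc(C)c(N2CCN(C(=O)c3oc(C)nc3-c3ccccc3Cl)CC2)c1`, which gives only a limit, > 1000 nM

Going by the values given here, compound 3 stands apart from the two numbered compounds: its result is a limit of the assay, not a number, and it is the one compound of three that sits at the limit of > 1000 nM in this assay, at which 1 of the 3 values shown sits. Among the compounds with values here, compounds 1 and 2 differ from each other by the pattern of the two methyl groups on the amine-bearing ring, and the step of a 4.2-fold lower number from compound 1 to compound 2 (0.62 log units; beyond the scatter) is the only measured step in the set.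

Compound 4 `Cc1ccc(C)c(N2CCN(C(=O)c3oc(C)nc3-c3ccccc3)CC2)c1` is not yet measured. It differs from compound 3 by hydrogen in place of chloro on an aromatic carbon. Within the data shown here, no measured step covers this change; the step from compound 1 to compound 2 concerns a different position and gives no direct guide. What can be said is that both compounds carrying the unsubstituted phenyl, compound 1 at 146 nM and compound 2 at 35 nM, return numbers, whereas compound 3 with the chloro does not. Compound 4 is therefore expected to move toward a measurable value, a step of an at least 4.0-fold lower number from compound 3 to compound 4 (0.60 log units; beyond the scatter), with wide uncertainty. The estimate for compound 4 is 250 nM, within 50 nM to 1500 nM.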

Compound 4, half-maximal inhibitory concentration: 31.3 nM
The estimate for compound 4 lay 8.0-fold (0.90 log units) above the measured number; measured number below the stated range.
By their numbers in this assay, from the lowest: compounds 4 and 2 (each within the scatter of the next); then compound 1. At a limit, above all of these: compound 3.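

In this assay, going by these compounds alone, 2-chlorophenyl to phenyl on the shared core gives an at least 31-fold lower number from compound 3 to compound 4 (1.50 log units; beyond the scatter), the first measured step at this position and the largest in the set. Compound 3 holds a limit of the assay, not a number, so this step is a bound and its true size stays unknown: the limit of > 1000 nM in this assay, at which 1 of the 4 values shown sits.

With phenyl kept, the methyl pattern on the amine-bearing ring still matters in part: a 4.7-fold lower number from compound 1 to compound 4 (0.67 log units; beyond the scatter) lies beyond the scatter, while a 1.1-fold lower number from compound 2 to compound 4 (0.05 log units; within the scatter) lies within it, so the 2,5-dimethylphenyl and 2,3-dimethylphenyl groups cannot be ordered here.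

From the compounds shown here alone, whether this drop is specific to chloro or follows from any group at this place stays open, and fluoro, methyl or methoxy on the same carbon would separate the two. The compounds shown also leave open how an amine or a carboxylic acid elsewhere on the phenyl ring would read.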